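From compound 2 to compound 3: methoxy replaces chloro

The source may hold more compounds than are shown below. What is called first, only, known or untested is meant among the compounds shown, and "the series" means these compounds.

Measured so far:
compound 1 `CCCCCCCCNc1nc(SCc2ccc(C(F)(F)F)cc2)nc2ccccc12`: 10500 nM
compound 2 `FC(F)(F)c1ccc(CSc2nc(Nc3ccccc3Cl)c3ccccc3n2)cc1`: 20400 nM

Both numbers come from a functional assay on PC-3 cells (Homo sapiens) for cytotoxicity, read by MTT assay, with a stated time of 72 h; on this read-out lower numbers stand for stronger inhibition and higher numbers for weaker inhibition. Compound 2 stands at the highest of the two numbers; the nearest is compound 1, and the step of a 1.9-fold higher number from compound 1 to compound 2 (0.29 log units; within the scatter) remains within the scatter. Compound 3 `COc1ccccc1Nc1nc(SCc2ccc(C(F)(F)F)cc2)nc2ccccc12` differs from compound 2 by methoxy in place of chloro on an aromatic carbon. Within the data shown here, no measured step touches a group on that ring; the only recorded step, a 1.9-fold higher number from compound 1 to compound 2 (0.29 log units; within the scatter), exchanges the whole group on the nitrogen and still lies within the scatter. The expected step is therefore small, none beyond the scatter: a 1.1-fold lower number from compound 2 to compound 3 (0.05 log units; within the scatter). For compound 3 the estimate is 18000 nM, within 7000 nM to 45000 nM.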

Compound 3, half-maximal inhibitory concentration: 14100 nM
The estimate for compound 3 lay 1.3-fold (0.11 log units) above the measured number; the range from low to high includes it.
By their numbers in this assay, from the lowest: compounds 1, 3 and 2 (each within the scatter of the next).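

In this assay, methoxy in place of chloro on an aromatic carbon, ortho to a large group, stays within the scatter (a 1.4-fold lower number from compound 2 to compound 3 (0.16 log units; within the scatter)). Among these compounds, the 2-methoxyphenyl group in place of octyl on the nitrogen also stays within the scatter (a 1.3-fold higher number from compound 1 to compound 3 (0.13 log units; within the scatter)), so neither this position nor this group separates the compounds so far. No evidence bears on the size of these steps.

Open: whether an amine or a carboxylic acid at this position would move the number beyond the scatter. From the compounds shown here alone, the effect of methoxy elsewhere on that ring also remains open.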